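The source may report more compounds than this note shows. Statements on the series, on what has been measured and on what is new or still open speak of the compounds shown alone.

In a functional assay on cells (Cancer cell lines, Homo sapiens) for cytotoxicity, read by sulforhodamine B assay, with a stated time of 48 h (a higher number here means a weaker inhibitor of growth, a lower number a stronger inhibitor of growth), compound 3 `CN(C)c1ccc(C2CC(c3ccccc3)=NN2C2=NC(=O)/C(=C3\C(=O)Nc4ccc(Br)cc43)S2)cc1` gives 200 nM, the second highest of the three numbers at hand. Its nearest neighbour, compound 1 `COc1ccc(C2CC(c3ccccc3)=NN2C2=NC(=O)/C(=C3\C(=O)Nc4ccc(Br)cc43)S2)cc1`, gives 190 nM in this assay, while compound 2 `CN(C)c1ccc(C2CC(c3ccccc3)=NN2C2=NC(=O)/C(=C3\C(=O)Nc4ccccc43)S2)cc1` gives 2550 nM. The step of a 1.1-fold higher number from compound 1 to compound 3 (0.02 log units; within the scatter) lies within the scatter, whereas a 13-fold lower number from compound 2 to compound 3 (1.11 log units; beyond the scatter) is large. Compound 4 `CN(C)c1ccc(C2CC(c3ccccc3)=NN2C2=NC(=O)/C(=C3\C(=O)Nc4ccc(Cl)cc43)S2)cc1` differs from compound 3 by chloro in place of bromo on an aromatic carbon. Going by the values given here, no measured step exchanges one halogen for another at this position; the only step there, a 13-fold lower number from compound 2 to compound 3 (1.11 log units; beyond the scatter), shows that a halogen matters greatly. Chloro, like bromo, keeps a halogen in place, so a change beyond the scatter is not expected, though the number may drift upward. Compound 4 is therefore estimated at 300 nM, between 120 nM and 800 nM, an expected step of a 1.5-fold higher number from compound 3 to compound 4 (0.18 log units; within the scatter).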

Compound 4, concentration for 50% growth inhibition: 190 nM
Beside the measured number, compound 4's estimate is 1.6-fold (0.20 log units) above it; the range from low to high includes it.
By their numbers in this assay, from the lowest: compounds 1, 4 and 3 (each within the scatter of the next); then compound 2.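

In this assay, going by these compounds alone, chloro in place of bromo on this aromatic carbon gives no change that stands out from the scatter (a 1.1-fold lower number from compound 3 to compound 4 (0.02 log units; within the scatter)), something no earlier pair could show. Against hydrogen at the same place, chloro also gives a large step (a 13-fold lower number from compound 2 to compound 4 (1.13 log units; beyond the scatter)), so the gain seen earlier is not confined to bromo. Going by these compounds, what fluoro, a methyl group or an amine would give on this aromatic carbon remains open. No evidence at hand explains why either halogen differs so much from hydrogen.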